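The source may report more compounds than this note shows. Statements on the series, on what has been measured and on what is new or still open speak of the compounds shown alone.

Three analogues sharing one core have been measured in an ADME assay on microsomes from liver (Homo sapiens) for metabolic stability, read by LC-MS, using NADPH, tested at 5 uM; on this read-out higher numbers stand for a longer-lived compound and lower numbers for a shorter-lived compound. Compound 1 `Cc1cc(-c2ccccc2)n(/C(N)=N/S(=O)(=O)c2cc(C)c(Cl)cc2SCc2cccc3ccccc23)n1` carries a naphthalen-1-yl group on a saturated chain carbon bound to a sulfur, and in this assay compound 1 gives 0.256 h. Compound 2 `Cc1ccc(CSc2cc(Cl)c(C)cc2S(=O)(=O)/N=C(\N)n2nc(C)cc2-c2ccccc2)cc1` has 4-methylphenyl at that place, and in this assay compound 2 gives 0.176 h. Compound 3 `Cc1cc(-c2ccccc2)n(/C(N)=N/S(=O)(=O)c2cc(C)c(Cl)cc2SCc2cccc(C(F)(F)F)c2)n1` has 3-(trifluoromethyl)phenyl at that place, and in this assay compound 3 gives 0.169 h. The steps of a 1.5-fold lower number from compound 1 to compound 2 (0.16 log units; within the scatter) and a 1.5-fold lower number from compound 1 to compound 3 (0.18 log units; within the scatter) both fall within the scatter, as does a 1.0-fold lower number from compound 2 to compound 3 (0.02 log units; within the scatter), so the number for compound 3 cannot be set apart from those of compound 1 and compound 2.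

Compound 4 `Cc1cc(-c2ccccc2)n(/C(N)=N/S(=O)(=O)c2cc(C)c(Cl)cc2SCc2ccc(C(F)(F)F)cc2)n1` differs from compound 3 only in the change (4-(trifluoromethyl)phenyl in place of 3-(trifluoromethyl)phenyl on a saturated chain carbon bound to a sulfur). For the measured compounds named here, no measured step moves the trifluoromethyl group around its ring; the nearest guides are the exchanges of whole aryl groups at that place, and each of those, a 1.0-fold lower number from compound 2 to compound 3 (0.02 log units; within the scatter) among them, stayed within the scatter. On that basis the step of a 1.0-fold higher number from compound 3 to compound 4 (0.00 log units; within the scatter) is expected to stay within the scatter as well. Compound 4 is therefore estimated to give 0.17 h in this assay, with a range from 0.09 h to 0.34 h.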

Compound 4, half-life: 0.241 h
Estimate against measurement, compound 4: 1.4-fold (0.15 log units) below; low and high end bracket the measured number.
By their numbers in this assay, from the lowest: compounds 3, 2, 4 and 1 (each within the scatter of the next).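

In this assay, for the compounds shown here, the shift of the trifluoromethyl group around its ring gave a 1.4-fold higher number from compound 3 to compound 4 (0.15 log units; within the scatter) and thus adds the first measured step at this position that keeps the same atoms and only joins them differently. The exchange of trifluoromethyl for methyl on an aromatic carbon gave a 1.4-fold higher number from compound 2 to compound 4 (0.14 log units; within the scatter) and the exchange of the whole aryl group gave a 1.1-fold lower number from compound 1 to compound 4 (0.03 log units; within the scatter) so that all four aryl groups on the saturated chain carbon bound to a sulfur now remain indistinguishable on this read-out, whether the change is a shift, a swap of one substituent or a swap of the whole group. Nothing measured alongside these half-lives speaks to what lies behind them.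

The compounds shown leave open whether an aryl group bearing an amine or a carboxylic acid, or a pyridine ring in its place, would move the half-life beyond the scatter at this position. They also leave open whether a longer chain between the sulfur and the ring would do so, and whether changes at any other place on the shared core would matter more.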